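Benzimidazole acetamides: aryl swap on the piperazine nitrogen

The compounds below may be only part of what the source reports. "The series", "measured", "known", "first", "only" and "open" are said of these compounds alone.

Measured so far:
compound 1, `O=C(CN1CCN(c2ccccc2F)CC1)Nc1nc2ccccc2[nH]1`, 70.6%
compound 2, `O=C(CN1CCN(c2ccc([N+](=O)[O-])cc2)CC1)Nc1nc2ccccc2[nH]1`, 76.7%

Going by the values given here, in a functional assay, read by spectrophotometry, with a stated time of 30 min, tested at 200 ug/mL (on this read-out higher numbers stand for a stronger effect at the one concentration tested and lower numbers for a weaker effect), compound 2 gives 76.7%, the higher of the two numbers so far; compound 1 gives 70.6%, and the one measured step, a number 6.1 percentage points higher from compound 1 to compound 2 (within the scatter), is within the scatter, so the two compounds are not distinguished on this read-out.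

Compound 3 is `COc1ccccc1N1CCN(CC(=O)Nc2nc3ccccc3[nH]2)CC1`, not yet measured. It differs from compound 2 in one place: 2-methoxyphenyl in place of 4-nitrophenyl on an amine nitrogen in a ring.

Among the compounds with values here, the only step that bears on this change is the one from compound 1 to compound 2, which also swaps the aryl group on the ring nitrogen and moves the number by a number 6.1 percentage points higher from compound 1 to compound 2 (within the scatter). Nothing measured separates the two aryl groups seen so far, and the incoming 2-methoxyphenyl is new to the set. The expectation is therefore a step of about a number 4.7 percentage points lower from compound 2 to compound 3 (within the scatter), that is no change beyond the scatter in this assay. Compound 3 is estimated at 72%, with a range from 58% to 86%.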

Compound 3, a percentage reported as activity, at one concentration (the size of the read-out at that concentration, not a potency): 64.5%
The estimate for compound 3 lay 7.5 percentage points above the measured number; the range from low to high includes it.
By their numbers in this assay, from the lowest: compounds 3, 1 and 2 (each within the scatter of the next, the first and the last beyond it).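

In this assay, going by these compounds alone, 2-methoxyphenyl in place of 4-nitrophenyl on the amine nitrogen in the ring gives a number 12.2 percentage points lower from compound 2 to compound 3 (beyond the scatter), the first step to pass beyond the scatter, so the aryl group at this position can shift the read-out, though only modestly. Methoxy in place of fluoro on an aromatic carbon gives a number 6.1 percentage points lower from compound 1 to compound 3 (within the scatter), which leaves compound 1 undistinguished from either of the other two compounds, so only the pair of 4-nitrophenyl and 2-methoxyphenyl compounds is separated. No measured evidence on hand accounts for the separation of this pair.

The step to compound 3 changes both the substituent and where it stands on the phenyl ring, and 4-methoxyphenyl and 2-nitrophenyl analogues would be needed to tell these two changes apart. Also open, as far as these compounds go, is how an unsubstituted phenyl, a benzyl or a simple alkyl chain on the same nitrogen would read, and, with a single concentration throughout, whether the stronger and weaker effects seen at that concentration would hold at any other.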